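This account rests on a few compounds, and the source may have more. Where it says the series, first, only, none or still open, it means among the compounds named here.

Among the compounds with values here, compound 1 `COC(=O)N1N=C(c2ccc(OC)cc2)CC1c1cc(OC)c(OC)c(OC)c1` is the only compound with a number in a functional assay on A549 cells (Homo sapiens) for antiproliferative activity, read by MTT assay, with a stated time of 48 h (a higher number here means a weaker inhibitor of growth, a lower number a stronger inhibitor of growth), where compound 1 gives 3400 nM. Compound 2 `CCCOC(=O)N1N=C(c2ccc(OC)cc2)CC1c1cc(OC)c(OC)c(OC)c1` reaches only a limit of this assay, at which compound 2 gives > 10000 nM. Within the data shown here, the sole measured step, an at least 2.9-fold higher number from compound 1 to compound 2 (0.46 log units; beyond the scatter), changes the saturated chain carbon and not the aromatic ring, so it does not bear on the change at hand. Compound 3 `COC(=O)N1N=C(c2ccc(OC)c(OC)c2)CC1c1cc(OC)c(OC)c(OC)c1` differs from compound 1 by methoxy in place of hydrogen on an aromatic carbon. Among the measured compounds shown here, with no measured step touching this position, compound 3 is expected near compound 1, at an estimated 3000 nM within 1000 nM to 10000 nM. The expected step is a 1.1-fold lower number from compound 1 to compound 3 (0.05 log units; within the scatter).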

Compound 3, concentration for 50% growth inhibition: 3930 nM
Estimate against measurement, compound 3: 1.3-fold (0.12 log units) below, and the stated range covers the measured number.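

The step to the 3,4-dimethoxyphenyl group, a 1.2-fold higher number from compound 1 to compound 3 (0.06 log units; within the scatter), shows that in this assay methoxy in place of hydrogen on this aromatic carbon, ortho to a methoxy group, leaves no difference that can be told from the scatter. Within the data shown here, this is the first reading at this position, and it extends the measured changes beyond the saturated chain carbon. Nothing at hand bears on why this step is so small. Going by these compounds, whether a hydroxyl, an amine or a chlorine at this position would read the same remains open. So does whether methoxy here would give the same result on the longer chain of compound 2.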